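A few compounds are considered here, and "the series" means these few. Any claim that something is new, unique, unknown or untested is made for them only; others in the source may bear on it.

In a functional assay on HL-60 cells (Homo sapiens) for cytotoxicity, read by luminescence and CellTiter-Glo, with a stated time of 3 days (on this read-out higher numbers stand for weaker inhibition and lower numbers for stronger inhibition), compound 1 `O=C(Nc1ccc(C(F)(F)F)cc1)c1cc(Cl)ccc1O` gives 510 nM, and compound 2 `O=C(Nc1ccc(C(F)(F)F)cc1)c1cc(Br)ccc1O` gives 580 nM. Compound 2 and compound 1 differ by chloro in place of bromo on an aromatic carbon, and that change made a 1.1-fold lower number from compound 2 to compound 1 (0.06 log units; within the scatter). Compound 3 `N#Cc1ccc(NC(=O)c2cc(Br)c(-c3ccccc3)cc2O)cc1` gives 700 nM in this assay. The difference between the core of compound 3 and the core of compound 2 is not broken down here, and the values of compound 3, compound 2 and compound 1 all lie within the scatter of one another, so no order among them can be read. Compound 4 `N#Cc1ccc(NC(=O)c2cc(Cl)c(-c3ccccc3)cc2O)cc1` has not yet been measured in this assay. It differs from compound 3 by chloro in place of bromo on an aromatic carbon, which is the same kind of change as that from compound 2 to compound 1, though here the place is also ortho to a phenyl group. Compound 4 is expected to show a 1.1-fold lower number from compound 3 to compound 4 (0.03 log units; within the scatter), an expectation that rests on a 1.1-fold lower number from compound 2 to compound 1 (0.06 log units; within the scatter). Compound 4 is therefore estimated at 650 nM, with a likely range from 350 nM to 1300 nM.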

Compound 4, half-maximal inhibitory concentration: 520 nM
For compound 4 the middle estimate is 1.3-fold (0.10 log units) above the measured one; low and high end bracket the measured number.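

In this assay, chloro in place of bromo on the core of compound 3 gave a 1.3-fold lower number from compound 3 to compound 4 (0.13 log units; within the scatter). Set beside the same change on the core of compound 2, the step shows no difference that can be read between the two cores: the same change on two cores in this assay, a 1.1-fold lower number (0.06 log units; within the scatter) from compound 2 to compound 1 and a 1.3-fold lower number (0.13 log units; within the scatter) from compound 3 to compound 4, 1.2-fold (0.07 log units) apart, within the scatter of two such steps This shows only that the change left the number within the scatter on both cores; it does not show that chloro and bromo differ in this series, and two small steps are a weak test of whether a real effect would carry from one core to another.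

The compounds shown leave open what a fluoro, a methyl or an amine would do in the place held by chloro and bromo. Also open, going by these compounds, is what the phenyl group contributes on its own and how a carboxylic acid would compare with the nitrile, as the cores of compound 2 and compound 3 differ in more than one place.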